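Pyridin-4-yl for a methyltriazolyl on the hydroxyl-bearing carbon

The source may report more compounds than this note shows. Statements on the series, on what has been measured and on what is new or still open speak of the compounds shown alone.

Compound 2 `Cn1cc([C@H](O)[C@H]2C(=O)N3C(C(=O)O)=C(C(C)(C)C)O[C@H]23)nn1` gives 7 h in an ADME assay, in phosphate buffer, at 28 degrees C, at pH 7.0 (a lower number here means that the compound disappears faster, a higher number that the compound lasts longer), and so stands at the top of the two numbers in hand, though only within the scatter of compound 1 `CC(C)(C)C1=C(C(=O)O)N2C(=O)[C@H]([C@H](O)c3ccncc3)[C@H]2O1`, which gives 6.4 h in this assay. Compound 3 `CC(C)(C)C1=C(C(=O)O)N2C(=O)[C@H]([C@@H](O)c3ccncc3)[C@H]2O1` differs from compound 2 by pyridin-4-yl in place of 1-methyl-1H-1,2,3-triazol-4-yl on a saturated chain carbon bound to an oxygen on a saturated carbon and a saturated ring carbon. Among the measured compounds shown here, no step between measured compounds is available, so the change carries no known size or direction. Compound 3 is therefore expected to show no shift beyond the scatter, a step of a 1.1-fold lower number from compound 2 to compound 3 (0.03 log units; within the scatter). Compound 3 is estimated at 6.5 h, between 4 h and 11 h.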

Compound 3, half-life: 6 h
For compound 3 the middle estimate is 1.1-fold (0.03 log units) above the measured one; measured number inside the range.
By their numbers in this assay, from the lowest: compounds 3, 1 and 2 (each within the scatter of the next).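

In this assay, pyridin-4-yl in place of 1-methyl-1H-1,2,3-triazol-4-yl gives a 1.2-fold lower number from compound 2 to compound 3 (0.07 log units; within the scatter), so this position does not tell the two aromatic rings apart. Configuration at this saturated chain carbon also makes no difference beyond the scatter, with a 1.1-fold lower number from compound 1 to compound 3 (0.03 log units; within the scatter). That second pair isolates the stereocentre alone: the fact that compounds 1 and 3 differ only in the configuration as drawn

Still open, going by these compounds, is whether an amine or a carboxylic acid in place of the aromatic ring would shift the half-life beyond the scatter. Equally open, on these data alone, is what a methoxy group in place of the hydroxyl on this carbon would do.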